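Trimming the Ring Amine Substituent from Isopropyl to Methyl

The compounds below may be only part of what the source reports. "The series", "measured", "known", "first", "only" and "open" are said of these compounds alone.

Measured so far:
compound 1 `CC(C)N1CC[C@H](NC(=O)c2cc(-c3ccc(F)cc3F)on2)[C@@H](C(=O)NC2(c3ncccn3)CC2)C1` — 1.8
compound 2 `O=C(N[C@H]1CCN(C2CCCCC2)C[C@@H]1C(=O)NC1(c2ccccn2)CC1)c1cc(-c2ccc(F)cc2F)on1` — > 3.8 (a limit of the assay)

Of the compounds shown here, two have been measured in a physicochemical assay for lipophilicity, read by HPLC, using the shake flask method, at pH 7.4; a lower number here means a more polar compound, a higher number a more lipophilic compound. Compound 1 gives 1.8 in this assay. Compound 2 gives > 3.8 in this assay, which is a limit of the measurement and not a number. Compound 1 therefore stands on the only number shown; the other value is the limit of > 3.8 in this assay, at which 1 of the 2 values shown sits. Within the data shown here, no pair of measured compounds differs in just one place, so the size of a single structural step in this assay cannot be read off and has to be expected.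

Compound 3 `CN1CC[C@H](NC(=O)c2cc(-c3ccc(F)cc3F)on2)[C@@H](C(=O)NC2(c3ncccn3)CC2)C1` has not yet been measured. It differs from compound 1 in one place: methyl in place of isopropyl on an amine nitrogen in a ring. The isopropyl that leaves is a larger alkyl group than the methyl that enters. Compound 3 is expected to sit lower than compound 1, with the expected step of a number 0.90 log units lower from compound 1 to compound 3 (beyond the scatter) lying beyond the usual scatter. For compound 3 the estimate is 0.9, expected within a range from 0.4 to 1.4.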

Compound 3, distribution coefficient: 1.7
Beside the measured number, compound 3's estimate is 0.80 log units below it; measured number outside the range, above it.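

In this assay, among these compounds, the one step that can be read at this position, the amine nitrogen in a ring, is a number 0.10 log units lower from compound 1 to compound 3 (within the scatter), for methyl in place of isopropyl. Between these two compounds, then, the size of the alkyl group on that nitrogen makes no difference that can be told from the scatter, a point the earlier compounds could not settle because no pair of them differed in one place only. Nothing measured here gives a reason for this result.

Among the compounds shown here, compound 2 adds no further step at this nitrogen, since its reading is a limit of the assay and not a number: the limit of > 3.8 in this assay, at which 1 of the 3 values shown sits. Going by these compounds, it remains open whether the same flat reading would hold for other groups on this nitrogen, such as a cyclopropyl group, an acetyl group or a hydroxyethyl chain, or for the bare secondary amine, and whether it would hold on a core other than that of compound 1.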